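Removing the Formyl Group on Two Biaryl Cores

A few compounds are considered here, and "the series" means these few. Any claim that something is new, unique, unknown or untested is made for them only; others in the source may bear on it.

Measured so far:
compound 1, `C=CCc1cc(C=O)c(OCC(=O)OCC)c(-c2ccc(OCC(=O)OCC)c(CC=C)c2)c1`, 86900 nM
compound 2, `C=CCc1ccc(OCC(=O)OCC)c(-c2ccc(OCC(=O)OCC)c(CC=C)c2)c1`, > 100000 nM
compound 3, `C=CCc1cc(C=O)c(OCC)c(-c2ccc(OCC)c(CC=C)c2)c1`, 37900 nM

In a functional assay on HUVEC cells (Homo sapiens) for antiproliferative activity, read by MTT assay, with a stated time of 24 h (on this read-out higher numbers stand for weaker inhibition and lower numbers for stronger inhibition), compound 1 gives 86900 nM. Compound 2 reaches a limit of this assay, > 100000 nM, and that limit is the limit of > 100000 nM in this assay, at which 1 of the 3 values shown sits. Compound 3 gives 37900 nM in this assay. The change hydrogen in place of formyl on an aromatic carbon makes the step of an at least 1.1-fold higher number from compound 1 to compound 2 (0.06 log units; that floor lies within the scatter). The difference between the core of compound 1 and the core of compound 3 is not broken down here.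

Compound 4, `C=CCc1ccc(OCC)c(-c2ccc(OCC)c(CC=C)c2)c1`, is not yet measured. It arises from compound 3 by hydrogen in place of formyl on an aromatic carbon, the same kind of change as from compound 1 to compound 2, but here the place is ortho to an ethoxy group rather than ortho to a (ethoxycarbonyl)methoxy group. Compound 4 is expected to move by a 1.6-fold higher number from compound 3 to compound 4 (0.20 log units; within the scatter), a step resting on the earlier one, an at least 1.1-fold higher number from compound 1 to compound 2 (0.06 log units; that floor lies within the scatter), which was small. Compound 4 is therefore estimated at 60000 nM, between 25000 nM and 150000 nM.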

Compound 4, half-maximal inhibitory concentration: > 100000 nM
Compound 4 ended at the assay's limit; the forecaster's own chance of this, stated with the estimate: 25%; middle value at least 1.6-fold (0.22 log units) from the limit.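

In this assay compound 4 stands at a limit of the assay, > 100000 nM, and that value is a limit, not a number. Hydrogen in place of formyl on this core gives an at least 2.6-fold higher number from compound 3 to compound 4 (0.42 log units; beyond the scatter), and the same change on the other core can be set beside it: the same change on two cores in this assay, an at least 1.1-fold higher number (0.06 log units; that floor lies within the scatter) from compound 1 to compound 2 and an at least 2.6-fold higher number (0.42 log units; beyond the scatter) from compound 3 to compound 4; the limit leaves it open whether they differ. Both compounds without the formyl group stand at the same limit, so the data show a shared end point, not a shared size of change: the limit of > 100000 nM in this assay, at which 2 of the 4 values shown sit.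

The compounds shown leave open whether a carboxylic acid, a nitrile or an amine on that aromatic carbon would behave as the formyl group does. They also leave open how a longer chain in place of the ethoxy group would read in this assay.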